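Furan-2-yl Replaces 2-Hydroxyphenyl on the Saturated Ring Carbon

The compounds below may be only part of what the source reports. "The series", "measured", "known", "first", "only" and "open" are said of these compounds alone.

Of the compounds shown here, three sharing one core have been tested in a functional assay on the whole organism for inhibition, with Rattus norvegicus as the target, read by paw edema, with stated times of 30 min and 1 h, at a dose of 10 mg/kg by the oral route; a lower number here means less inhibition, a higher number more inhibition at the dose given (going by the name of the read-out). Compound 1 `O=C1N=C(C2C(=O)c3ccccc3C2=O)CC(c2ccc([N+](=O)[O-])cc2)N1` carries a 4-nitrophenyl group and gives 16%. Compound 2 `O=C1N=C(C2C(=O)c3ccccc3C2=O)CC(/C=C/c2ccccc2)N1` carries a 2-phenylethenyl group and gives 17%. Compound 3 `O=C1N=C(C2C(=O)c3ccccc3C2=O)CC(c2ccccc2O)N1` carries a 2-hydroxyphenyl group and gives 24%. On these numbers compound 3 has the highest value of the three, but both of its gaps lie within the scatter: a number 7 percentage points higher from compound 2 to compound 3 (within the scatter) and a number 8 percentage points higher from compound 1 to compound 3 (within the scatter). The remaining pair also stays within the scatter, a number 1 percentage points higher from compound 1 to compound 2 (within the scatter). So far the three groups on the saturated ring carbon have not produced any difference in this assay that can be told from the usual variation of repeated measurements.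

Compound 4 `O=C1N=C(C2C(=O)c3ccccc3C2=O)CC(c2ccco2)N1` differs from compound 3 in one place: furan-2-yl in place of 2-hydroxyphenyl on a saturated ring carbon. Among the measured compounds shown here, no measured step involves a furan-2-yl group, so none bears directly on this change; what the record shows is that exchanging one such group for another on this saturated ring carbon moved this assay by amounts within the scatter each time. The step to compound 4 is therefore expected to be of the same kind, a number 4 percentage points lower from compound 3 to compound 4 (within the scatter), with no direction beyond the scatter. Compound 4 is accordingly estimated to give 20% in this assay, in a range from 8% to 32%.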

Compound 4, a percentage reported as inhibition, in the whole organism at one dose (the size of the read-out at that dose, not a potency): 18%
Estimate against measurement, compound 4: 2 percentage points above; the range from low to high includes it.
By their numbers in this assay, from the lowest: compounds 1, 2, 4 and 3 (each within the scatter of the next).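

Furan-2-yl brings a five-membered aromatic ring with 1 hetero atom onto the saturated ring carbon, and in this assay the three new steps are a number 6 percentage points lower from compound 3 to compound 4 (within the scatter), a number 1 percentage points higher from compound 2 to compound 4 (within the scatter) and a number 2 percentage points higher from compound 1 to compound 4 (within the scatter). The first of these steps also removes the hydrogen-bond donor counted on 2-hydroxyphenyl, and even this exchange, which replaces a six-membered aromatic ring of carbon only, cannot be told from the usual variation, so all six pairs among the four groups now lie within the scatter. Nothing available accounts for these values or shows what the groups do at this position.

It remains open whether any group on this saturated ring carbon can move the paw edema read-out beyond the scatter, since the four compounds shown do not include one there with an amine, a carboxylic acid or a longer saturated alkyl chain. Also open, from the compounds shown here alone, is whether changes elsewhere on the shared core would give a step that can be told from the scatter, as all four compounds differ only at this one carbon.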